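Fluoro scan on the dihydronaphthalene imidazoline core

The source may report more compounds than this note shows. Statements on the series, on what has been measured and on what is new or still open speak of the compounds shown alone.

Compound 1 `C1=NCC(CC2=Cc3ccccc3CC2)N1` carries the unsubstituted aromatic ring of the shared core; in an assay on isolated protein for binding affinity to Adrenergic receptor alpha-1 (Rattus norvegicus), read by radioligand binding, in the presence of a further agent that is not named here (on this read-out lower numbers stand for stronger inhibition and higher numbers for weaker inhibition), compound 1 gives 398 nM. Among the three measured compounds it holds the second highest number: compound 3 `Cc1cccc2c1C=C(CC1CN=CN1)CC2` gives 631 nM, and the step of a 1.6-fold higher number from compound 1 to compound 3 (0.20 log units; within the scatter) stays within the scatter, while compound 2 `COc1cccc2c1C=C(CC1CN=CN1)CC2` gives 158 nM, a step of a 2.5-fold lower number from compound 1 to compound 2 (0.40 log units; beyond the scatter). Between the two substituted analogues the step is a 4.0-fold higher number from compound 2 to compound 3 (0.60 log units; beyond the scatter).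

Compound 4 `Fc1ccc2c(c1)C=C(CC1CN=CN1)CC2` differs from compound 1 by fluoro in place of hydrogen on an aromatic carbon. The two measured steps from compound 1 both concern a substituent on the same aromatic ring, but at another aromatic carbon, and they point in opposite directions; neither is a fluoro. They show that a single small group on this ring moves this assay only modestly. A step within the scatter is therefore expected, a 1.0-fold higher number from compound 1 to compound 4 (0.00 log units; within the scatter), with no clear direction. For compound 4 the expected value in this assay is 400 nM, estimated within the range 160 nM to 1000 nM.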

Compound 4, inhibition constant: 251 nM
For compound 4 the middle estimate is 1.6-fold (0.20 log units) above the measured one; low and high end bracket the measured number.
By their numbers in this assay, from the lowest: compounds 2, 4, 1 and 3 (each within the scatter of the next, the first and the last beyond it).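

Fluoro on this aromatic carbon, meta to a fused ring and para to a fused ring, gives the series its first reading at this place: in this assay there is a 1.6-fold lower number from compound 1 to compound 4 (0.20 log units; within the scatter) and so no direction can be assigned to the change. A fluoro in place of hydrogen here therefore leaves the number of the unsubstituted core within the scatter, whereas methoxy on the other aromatic carbon gives a 2.5-fold lower number from compound 1 to compound 2 (0.40 log units; beyond the scatter) and does move beyond it. Nothing available bears on the reason for this result.

As far as these compounds go, whether methoxy or methyl at this carbon would behave as they do at the other aromatic carbon stays open, as does the reading for fluoro at that other carbon. From the compounds shown here alone, what an amine, a carboxylic acid or trifluoromethyl would do at this place also remains open.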